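A Smaller Halogen on the Aromatic Nitrogen's Phenyl

The source may report more compounds than this note shows. Statements on the series, on what has been measured and on what is new or still open speak of the compounds shown alone.

Of the compounds shown here, three with a shared core have been tested in a functional assay on K562 cells (Homo sapiens) for antiproliferative activity, read by MTT assay, with a stated time of 72 h; a higher number here means a weaker inhibitor, a lower number a stronger inhibitor. Compound 1 `COc1cc(-n2ncnc2-c2ccc(OC(C)C)cc2)cc(OC)c1OC` gives 800 nM. For compound 2 `COc1cc(-c2ncnn2-c2ccc(Cl)c(Cl)c2)cc(OC)c1OC` the result is only a limit, > 10000 nM. Compound 3 `COc1cc(-n2ncnc2-c2cccc(Cl)c2)cc(OC)c1OC` likewise reaches only a limit, > 10000 nM. Compound 2 thus stands at the limit of > 10000 nM in this assay, at which 2 of the 3 values shown sit, sharing that position with compound 3, while compound 1 alone shows a measured number. The untested compound 4 `COc1cc(-c2ncnn2-c2cccc(F)c2)cc(OC)c1OC` carries 3-fluorophenyl in place of 3,4-dichlorophenyl on an aromatic nitrogen. Among the measured compounds shown here, no measured step between two compounds exists here to show how large such a change tends to be. Compound 4 is expected to stay weak, most likely again at the limit, so the step that the limit leaves unreadable from compound 2 to compound 4 in this assay is estimated to lie within the scatter. Compound 4 is expected at 12000 nM, within 3000 nM to 40000 nM.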

Compound 4, half-maximal inhibitory concentration: > 10000 nM
Compound 4 ended at the assay's limit (the forecaster's own chance of this, stated with the estimate: 70%); the middle value does not contradict the limit.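

Compound 2 and compound 4 both end at a limit rather than a number, so no step between them can be read: the limit of > 10000 nM in this assay, at which 3 of the 4 values shown sit.

The compounds shown leave open whether 3-fluorophenyl and 3,4-dichlorophenyl differ in antiproliferative activity at this place.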